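The compounds below may be only part of what the source reports. "The series", "measured", "known", "first", "only" and "open" are said of these compounds alone.

Measured compounds in an assay on cells for displacement of a labelled ligand from adenosine receptor A2b (Homo sapiens), read by scintillation counting and radioligand binding, with a stated time of 30 min, tested at 10 uM; on this read-out higher numbers stand for more inhibition at the one concentration tested (going by the name of the read-out) and lower numbers for less inhibition:
- compound 1 `CN1CCN(c2nc(-c3cccc(Cl)c3)nc3[nH]cnc23)CC1`: compound 1 gives 29.9%
- compound 2 `CN1CCN(c2nc(-c3cccc(Cl)c3)nc3c2ncn3C)CC1`: compound 2 gives 19.2%
- compound 3 `Clc1cccc(-c2nc(N3CCCCC3)c3nc[nH]c3n2)c1`: compound 3 gives > 80%; this value is a limit of this assay, not a number the limit of > 80% in this assay, at which 1 of the 3 values shown sits.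

Among the two numbers in this assay, compound 1 stands highest; the nearest is compound 2, and the step of a number 10.7 percentage points lower from compound 1 to compound 2 (beyond the scatter) lies beyond the scatter. The step of a number at least 50.1 percentage points higher from compound 1 to compound 3 (beyond the scatter) runs to a limit and is therefore known only as a lower bound on its size.

Compound 4 `CN1CCN(c2nc(-c3ccc(O)cc3)nc3[nH]cnc23)CC1` is not yet measured in this assay. It differs from compound 1 in one place: 4-hydroxyphenyl in place of 3-chlorophenyl on an aromatic carbon. Neither measured step bears directly on this change. The step from compound 1 to compound 2 touches the aromatic nitrogen, and the step from compound 1 to compound 3 touches the 4-methylpiperazin-1-yl group; the aryl group carrying the chlorine is the same in compounds 1, 2 and 3, so its contribution is unobserved in this set. Among the compounds with values here, with no measured step on the aryl group, the expected step of a number 7.9 percentage points lower from compound 1 to compound 4 (within the scatter) is taken as small, with wide uncertainty. For compound 4 the estimate in this assay is 22%, within 2% to 50%.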

Compound 4, a percentage reported as inhibition, at one concentration (the size of the read-out at that concentration, not a potency): 53%
Compound 4: middle estimate off by 31 percentage points, on the low side; the whole stated range lies below it.
By their numbers in this assay, from the lowest: compound 2; then compound 1; then compound 4. At a limit, above all of these: compound 3.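

In this assay, 4-hydroxyphenyl in place of 3-chlorophenyl gives a number 23.1 percentage points higher from compound 1 to compound 4 (beyond the scatter), so the aromatic carbon between two ring nitrogen atoms is a place where the read-out responds, which compound 1, compound 2 and compound 3, all sharing one aryl group, could not show. Within the data shown here, with the 4-methylpiperazin-1-yl group kept, a change on the aryl group alone moves the number beyond the scatter, so the swap to piperidin-1-yl is no longer the only single change seen to raise it. The step joins two changes, the substituent and its place on the phenyl ring, which cannot be separated here, and no measured property in hand speaks to its cause.

Still open, as far as these compounds go, is which of the two changes carries the step: 3-hydroxyphenyl, 4-chlorophenyl or unsubstituted phenyl on the same core would separate them, and a methoxy or an amino group in place of the hydroxyl would test the hydroxyl itself. From the compounds shown here alone, compound 3 gives > 80%, a limit of this assay, and whether 4-hydroxyphenyl adds anything alongside piperidin-1-yl remains unknown.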